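The source may hold more compounds than are shown below. What is called first, only, known or untested is meant among the compounds shown, and "the series" means these compounds.

Compound 1 `O=C(/C=C/c1ccc(O)cc1)c1c(O)cccc1OCCC1CCCCC1`: > 30000 nM
Compound 2 `CCCCOc1cccc(O)c1C(=O)/C=C/c1ccc(O)cc1`: > 30000 nM

In an assay on THP-1 cells for inhibition of nuclear factor NF-kappa-B complex (Homo sapiens), with stated times of 2 h and 16 h (a higher number here means a weaker inhibitor, a lower number a stronger inhibitor), compound 1 gives > 30000 nM, which is a limit of the assay and not a measured number. Compound 2 gives > 30000 nM in this assay, again a limit. Within the data shown here, the one change between them, a step that the two limits leave unreadable from compound 1 to compound 2, therefore has no readable size, because both ends sit at the same limit (the limit of > 30000 nM in this assay, at which 2 of the 2 values shown sit). Among the measured compounds shown here, compound 2 thus stands at the limit of this assay, with no number of its own, and the only other value shown stands there too.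

Compound 3 `CC(C)COc1cccc(O)c1C(=O)/C=C/c1ccc(O)cc1` differs from compound 2 in one place: isopropyl in place of propyl on a saturated chain carbon bound to an oxygen on an aromatic ring. For the measured compounds named here, the only measured step, from compound 1 to compound 2, is unreadable, so nothing among the measured compounds tells in which direction or by how much this rearrangement of the same atoms should move the result in this assay. Given that both shown values sit at the limit (the limit of > 30000 nM in this assay, at which 2 of the 2 values shown sit), compound 3 is expected to stay near that limit too, meaning an expected step of a number no higher from compound 2 to compound 3 (the limit leaves the size open). For compound 3 the estimate in this assay is 30000 nM, with a range from 8000 nM to 100000 nM.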

Compound 3, half-maximal inhibitory concentration: 8000 nM
Estimate against measurement, compound 3: 3.8-fold (0.57 log units) above; measured number inside the range.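

In this assay, the chain on this aromatic oxygen now proves able to move the result: going from butoxy to isobutoxy, the same atoms joined differently, gives an at least 3.7-fold lower number from compound 2 to compound 3 (0.57 log units; beyond the scatter). Setting isobutoxy in place of the chain ending in a cyclohexyl ring gives an at least 3.7-fold lower number from compound 1 to compound 3 (0.57 log units; beyond the scatter), while the step between compound 1 and compound 2 remains unreadable, so the branched chain of compound 3 is the only one here that separates from the others. Compound 3 is also the only one of the three with a measured number, and the other two stand at a limit: the limit of > 30000 nM in this assay, at which 2 of the 3 values shown sit.

With a single branched chain shown, it remains open whether branching in general helps or only this particular isobutyl shape does, and an isopropoxy or tert-butoxy group could move the number either way. Also open, going by these compounds, is whether an amine or a carboxylic acid on this chain would keep, lose or improve on the value of compound 3, 8000 nM, and whether a longer branched chain would do the same.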